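The source may report more compounds than this note shows. Statements on the series, on what has been measured and on what is new or still open speak of the compounds shown alone.

Compound 2 `CN(C(=O)NC(=O)c1ccccc1F)c1nc(C(F)(F)F)c(C(=O)N/N=C/c2ccccc2C(F)(F)F)s1` and compound 1 `CN(C(=O)NC(=O)c1ccc(C(F)(F)F)cc1)c1nc(C(F)(F)F)c(C(=O)N/N=C/c2cccc(C(F)(F)F)c2)s1` are built on the same core and differ from each other at two places. In a functional assay on HepG2 cells (Homo sapiens) for inhibition, read by MTT assay, with a stated time of 72 h (a lower number here means a stronger inhibitor, a higher number a weaker inhibitor), compound 2 gives 5.39 ug/mL, and compound 1 gives 7.95 ug/mL, two numbers that lie within the usual scatter of each other. Compound 3 `CN(C(=O)NC(=O)c1ccc(C(F)(F)F)cc1)c1nc(C(F)(F)F)c(C(=O)N/N=C/c2ccccc2C(F)(F)F)s1` differs from compound 2 by a single change, (4-(trifluoromethyl)phenyl in place of 2-fluorophenyl on a carbonyl carbon), and so carries at that carbonyl the same group as compound 1. Among the compounds with values here, no single-change step has been measured in this small set; the expected step, a 1.2-fold higher number from compound 2 to compound 3 (0.08 log units; within the scatter), stays within the scatter. Compound 3 is therefore estimated at 6.5 ug/mL, with a range from 3.2 ug/mL to 13 ug/mL.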

Compound 3, half-maximal inhibitory concentration: 3.64 ug/mL
Compound 3: middle estimate off by 1.8-fold (0.25 log units), on the high side, and the stated range covers the measured number.
By their numbers in this assay, from the lowest: compounds 3, 2 and 1 (each within the scatter of the next, the first and the last beyond it).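

On the carbonyl carbon, 4-(trifluoromethyl)phenyl in place of 2-fluorophenyl gives (a 1.5-fold lower number from compound 2 to compound 3 (0.17 log units; within the scatter)), so this assay does not separate these two groups at this position. Within the data shown here, on the carbon with a double bond to nitrogen, 2-(trifluoromethyl)phenyl in place of 3-(trifluoromethyl)phenyl gives (a 2.2-fold lower number from compound 1 to compound 3 (0.34 log units; beyond the scatter)), a modest step and the first single change here that goes beyond the scatter. Nothing available explains either step.

Still open, from the compounds shown here alone, is whether this second step holds with other groups on the carbonyl carbon. Also open, going by these compounds, is how an amine or a carboxylic acid would read at either position.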